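This account rests on a few compounds, and the source may have more. Where it says the series, first, only, none or still open, it means among the compounds named here.

In a functional assay on Jurkat cells (Homo sapiens) for inhibition (on this read-out higher numbers stand for weaker inhibition of growth and lower numbers for stronger inhibition of growth), three related compounds have been measured so far. Compound 1 `Clc1ccc(-c2nn(-c3ccccc3)c3ncncc23)cc1` gives 36000 nM, compound 2 `Cc1ccc(-c2nn(-c3ccc4ccccc4n3)c3ncncc23)cc1` gives 54000 nM, and compound 3 `Clc1ccc(-c2nn(-c3ccc4ccccc4n3)c3ncncc23)cc1` gives 69000 nM. These three values lie within the usual scatter of one another, so compound 3 does not stand apart from the other two.

Compound 4 `COc1ccc(-c2nn(-c3ccc4ccccc4n3)c3ncncc23)cc1` keeps all of compound 3 except one group: methoxy in place of chloro on an aromatic carbon. The change is 4-chlorophenyl to 4-methoxyphenyl, with methoxy in place of chloro on an aromatic carbon, para to a large group. Among the measured compounds shown here, only one measured step involves a swap at that place, chloro in place of methyl, and it gave a 1.3-fold higher number from compound 2 to compound 3 (0.11 log units; within the scatter), so no step beyond the scatter is expected in this assay, in either direction. Going by these compounds, one measured swap is thin evidence, and methoxy itself is untested. The estimated change is a 1.3-fold lower number from compound 3 to compound 4 (0.10 log units; within the scatter). For compound 4 the expected value is 55000 nM, with an estimated range from 25000 nM to 110000 nM.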

Compound 4, concentration for 50% growth inhibition: > 100000 nM
Compound 4: only a limit was reported; the forecaster's own chance of this, stated with the estimate: 10%; middle value at least 1.8-fold (0.25 log units) away from the limit.
By their numbers in this assay, from the lowest: compounds 1, 2 and 3 (each within the scatter of the next). At a limit, above all of these: compound 4.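

In this assay compound 4 gives > 100000 nM, which is a limit of the assay and not a number. At this aromatic carbon, para to a large group, putting methoxy in place of chloro gives an at least 1.4-fold higher number from compound 3 to compound 4 (0.16 log units; that floor lies within the scatter), and putting methoxy in place of methyl gives an at least 1.8-fold higher number from compound 2 to compound 4 (0.26 log units; that floor lies within the scatter). Unlike the earlier swap of chloro for methyl, this change has no known upper end, so its true size could be small or large, and compound 4 is alone in this: the limit of > 100000 nM in this assay, at which 1 of the 4 values shown sits.

Going by these compounds, it remains open whether an amine, a hydroxyl or a fluoro at this place would shift the number beyond the scatter in either direction. On these data alone, it is also open whether methoxy would give a measurable number on the core of compound 1.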